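Benzyl to 3-Chlorophenyl on a Ring Amine Nitrogen

The source may report more compounds than this note shows. Statements on the series, on what has been measured and on what is new or still open speak of the compounds shown alone.

Measured in an ADME assay on MT4 cells (Homo sapiens) for cytotoxicity, read by MTT assay, with a stated time of 5 days; a lower number here means that less compound is tolerated, a higher number that more compound is tolerated:
compound 1 `COc1cc(Cc2cnc(/N=C3\C(=O)N(CN4CCN(Cc5ccccc5)CC4)c4ccc(Cl)cc43)nc2N)cc(OC)c1OC` gives 36.1 ug/mL
compound 2 `CCn1cc(C(=O)O)c(=O)c2cc(F)c(N3CCN(CN4C(=O)/C(=N\c5ncc(Cc6cc(OC)c(OC)c(OC)c6)c(N)n5)c5cc(Cl)ccc54)C(C)C3)c(F)c21` gives 36.9 ug/mL
compound 3 `CCCCN(CCCC)CN1C(=O)/C(=N\c2ncc(Cc3cc(OC)c(OC)c(OC)c3)c(N)n2)c2cc(Cl)ccc21` gives 62.6 ug/mL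

Compound 1 stands alongside the other two rather than apart from them: its gap to compound 2 and its gap to compound 3 both fall within the usual scatter of this assay, so the three numbers cannot be told apart. Compound 4 `COc1cc(Cc2cnc(/N=C3\C(=O)N(CN4CCN(c5cccc(Cl)c5)CC4)c4ccc(Cl)cc43)nc2N)cc(OC)c1OC` has not yet been measured. It differs from compound 1 in one place only: 3-chlorophenyl in place of benzyl on an amine nitrogen in a ring. Among the compounds with values here, no pair of measured compounds shows what this kind of change does in this assay, so there is no measured step to lean on. Given how closely the three measured values sit together, the expectation for compound 4 is a small shift at most, with a slight lean toward less compound being tolerated, while staying within the scatter. The estimated step from compound 1 to compound 4 is a 1.2-fold lower number from compound 1 to compound 4 (0.08 log units; within the scatter). Compound 4 is thus expected to give about 30 ug/mL in this assay, within a range from 15 ug/mL to 60 ug/mL.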

Compound 4, half-maximal cytotoxic concentration: 39.2 ug/mL
Compound 4: middle estimate off by 1.3-fold (0.12 log units), on the low side, within the range that was stated.
By their numbers in this assay, from the lowest: compounds 1, 2, 4 and 3 (each within the scatter of the next).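

Within the data shown here, putting 3-chlorophenyl in place of benzyl on the amine nitrogen in the ring gives, in this assay, a 1.1-fold higher number from compound 1 to compound 4 (0.04 log units; within the scatter), and this is the first direct comparison of two compounds that differ only at this position. The step lies within the scatter, so this exchange between two groups of equal heavy-atom count, each with one six-membered aromatic ring of carbon only, has no effect that this measurement can distinguish. No measurement shown here bears on what lies behind this result.

A single pair cannot show whether this nitrogen tolerates every group equally. An unsubstituted phenyl would separate the chlorine from the change of benzyl to an aryl group, while a small methyl or a hydroxyethyl chain would test groups without an aromatic ring.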